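Compound 4: (1-phenylethyl)amino on a carbonyl carbon

The source may hold more compounds than are shown below. What is called first, only, known or untested is meant among the compounds shown, and "the series" means these compounds.

Values in a functional assay on HL-60 cells (Homo sapiens) for antiproliferative activity, read by MTT assay, with a stated time of 24 h (on this read-out higher numbers stand for weaker inhibition and lower numbers for stronger inhibition), follow, and each one is a limit, not a number.

- Compound 1 `CCCCNC(=O)COc1ccc(C(=O)c2c(CCCC)oc3ccccc23)cc1` gives > 50000 nM (a limit)
- Compound 2 `CCCCc1oc2ccccc2c1C(=O)c1ccc(OCC(=O)N2CCCC2)cc1` gives > 50000 nM (a limit)
- Compound 3 `CCCCc1oc2ccccc2c1C(=O)c1ccc(OCC(=O)N2CCN(C(=O)OC(C)(C)C)CC2)cc1` gives > 50000 nM (a limit)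

Compound 2 has no readable value, so its place is known only from the limit of > 50000 nM in this assay, at which 3 of the 3 values shown sit, and from nothing finer. Compound 4 `CCCCc1oc2ccccc2c1C(=O)c1ccc(OCC(=O)N[C@@H](C)c2ccccc2)cc1` keeps the shared core. Its whole difference from compound 2 is (1-phenylethyl)amino in place of pyrrolidin-1-yl on a carbonyl carbon and the change, in short, puts (1-phenylethyl)amino in place of pyrrolidin-1-yl on a carbonyl carbon.

The closest measured change is a step that the two limits leave unreadable from compound 1 to compound 2 and it offers no size to carry over. Compound 1, compound 2 and compound 3 carry different groups on that carbonyl carbon, yet none gives a number. No step beyond the scatter is therefore expected, and no direction can be claimed. The expected move in this assay is a number no higher from compound 2 to compound 4 (the limit leaves the size open) and it rests on very little. For compound 4 the estimate is 50000 nM with an expected range from 15000 nM to 120000 nM and another report of the limit remains the likeliest outcome.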

Compound 4, half-maximal inhibitory concentration: > 50000 nM
Compound 4: no number, only a limit; the forecaster's own chance of this, stated with the estimate: 70%; the middle value sits exactly at the limit.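

The steps from compound 1 and from compound 2 to compound 4 cannot be read, because each value is only a limit, not a number: the limit of > 50000 nM in this assay, at which 4 of the 4 values shown sit.

The compounds shown leave open whether any group on that carbonyl carbon would give a readable number in this assay.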